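The source may hold more compounds than are shown below. What is called first, only, known or untested is meant among the compounds shown, and "the series" means these compounds.

Measured compounds:
compound 1, `CCOc1ccc2nc(C(F)(F)F)cc(OCC(=O)Nc3cc(C)cc(C)c3)c2c1`: < 1000 nM
compound 2, `COc1ccc2nc(C)cc(OCCNc3cc(C)cc(C)c3)c2c1`: 33000 nM
compound 3, `COc1ccc(NC(=O)COc2cc(C)nc3ccc(OC)cc23)cc1`: 108000 nM

Of the compounds shown here, three sharing one core have been measured in a physicochemical assay for solubility, in phosphate buffer, measured as kinetic solubility, with a stated time of 1 h, at pH 7.4; on this read-out lower numbers stand for lower solubility and higher numbers for higher solubility. Compound 1 reaches only a limit of the assay, < 1000 nM. For compound 1 the reading is the limit of < 1000 nM in this assay, at which 1 of the 3 values shown sits, not a number. Compound 2 gives 33000 nM in this assay. Compound 3 gives 108000 nM in this assay, the highest of the two numbers shown, with compound 2 the nearest and its number lower by a gap beyond the scatter.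

Compound 4, `COc1ccc2nc(C)cc(OCC(=O)Nc3cc(C)nc(C)n3)c2c1`, has not yet been measured in this assay. It differs from compound 3 in one place: 2,6-dimethylpyrimidin-4-yl in place of 4-methoxyphenyl on an amide-type nitrogen. For the measured compounds named here, no measured pair in this set reports such a change, so the size of the step can only be estimated. The account expects a small step from compound 3 to compound 4 in this assay, upward if anything, of the size a 1.2-fold higher number from compound 3 to compound 4 (0.08 log units; within the scatter), and not clearly beyond the scatter. Compound 4 is therefore estimated at 130000 nM in this assay, with a range from 40000 nM to 400000 nM.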

Compound 4, solubility: 5000 nM
Compound 4: the middle estimate sits 26-fold (1.41 log units) above what was measured; measured number outside the range, below it.
By their numbers in this assay, from the lowest: compound 4; then compound 2; then compound 3. At a limit, below all of these: compound 1.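

In this assay, the group on the amide-type nitrogen proves to be a sensitive place: 2,6-dimethylpyrimidin-4-yl in place of 4-methoxyphenyl gives a 22-fold lower number from compound 3 to compound 4 (1.33 log units; beyond the scatter). The earlier compounds shown here offered no pair differing in one place, so they could not show that this exchange, between six-membered aromatic rings of equal heavy-atom count and no net charge, can produce a large step. Nothing measured here bears on why the number falls.

The compounds shown leave open whether the step follows the ring nitrogens or the methyl groups of the new group, and where an unsubstituted pyrimidin-4-yl or a 2,6-dimethylphenyl group on the same nitrogen would fall. From the compounds shown here alone, it also remains open how a morpholine attached to that ring would read in this assay.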